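A few compounds are considered here, and "the series" means these few. Any claim that something is new, unique, unknown or untested is made for them only; others in the source may bear on it.

Going by the values given here, compound 1 `CCOC(=O)NC(=O)NC1=CS(=O)(=O)O[C@@]12[C@@H](CO[Si](C)(C)C(C)(C)C)O[C@@H](n1cc(C)c(=O)n(C)c1=O)[C@@H]2O[Si](C)(C)C(C)(C)C` gives 14000 nM in a functional assay on HEL cells (Homo sapiens) (a higher number here means that more compound is tolerated, a lower number that less compound is tolerated), the lower of the two numbers known so far. Compound 2 `Cc1cn([C@@H]2O[C@H](CO[Si](C)(C)C(C)(C)C)[C@@]3(OS(=O)(=O)C=C3NCCC(=O)OCc3ccccc3)[C@H]2O[Si](C)(C)C(C)(C)C)c(=O)n(C)c1=O` gives 200000 nM in this assay, and the step of a 14-fold higher number from compound 1 to compound 2 (1.15 log units; beyond the scatter) came with 2-(benzyloxycarbonyl)ethyl in place of (ethoxycarbonyl)carbamoyl on an amine nitrogen. Compound 3 `Cc1cn([C@@H]2O[C@H](CO[Si](C)(C)C(C)(C)C)[C@@]3(OS(=O)(=O)C=C3NCC(=O)C(N)=O)[C@H]2O[Si](C)(C)C(C)(C)C)c(=O)n(C)c1=O` differs from compound 1 by one change: (carbamoylcarbonyl)methyl in place of (ethoxycarbonyl)carbamoyl on an amine nitrogen. Among the compounds with values here, only that one earlier step bears on this change, and it moved upward, so an upward step is expected here too, though the entering group differs from that of compound 2 and the size is uncertain. The estimate for compound 3 is 40000 nM, ranging from 10000 nM to 160000 nM. That estimate means an expected step of a 2.9-fold higher number from compound 1 to compound 3 (0.46 log units; beyond the scatter).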

Compound 3, half-maximal cytotoxic concentration: 14500 nM
For compound 3 the middle estimate is 2.8-fold (0.44 log units) above the measured one; measured number inside the range.
By their numbers in this assay, from the lowest: compounds 1 and 3 (each within the scatter of the next); then compound 2.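

Putting (carbamoylcarbonyl)methyl in place of (ethoxycarbonyl)carbamoyl on the amine nitrogen gives a 1.0-fold higher number from compound 1 to compound 3 (0.02 log units; within the scatter) in this assay, so losing (ethoxycarbonyl)carbamoyl does not by itself raise the number. The entering group matters: carbamoylcarbonyl in place of (benzyloxycarbonyl)methyl gives a 14-fold lower number from compound 2 to compound 3 (1.14 log units; beyond the scatter) on the same chain. No measurement at hand explains this difference. Which part of (benzyloxycarbonyl)methyl goes with the higher number stays open, and so does what a free carboxylic acid or an amine at that chain end would give.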